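Trimming a Crowded Aryl Ring and Cell Tolerance

This account rests on a few compounds, and the source may have more. Where it says the series, first, only, none or still open, it means among the compounds named here.

Compound 1 `Cc1oc(-c2c(C)c(C)c(C)c(C)c2C)nc1CN1CCC(C(=O)NCCCN2C[C@H](C)C[C@H](C)C2)CC1` belongs to a small set of three compounds that share a common core. In an ADME assay on Huh7.5.1 cells (Homo sapiens) for cytotoxicity, read by ATP content, with a stated time of 48 h (a lower number here means that less compound is tolerated, a higher number that more compound is tolerated), compound 1 gives 8180 nM. Compound 2 `Cc1ccccc1-c1nc(CN2CCC(C(=O)NCCCN3CC(C)(C)CC(C)(C)C3)CC2)c(C)o1` gives 4380 nM in this assay, and compound 3 `Cc1cccc(Cl)c1-c1nc(CN2CCC(C(=O)NCCCN3CCCC(C)C3)CC2)c(C)o1` gives 16400 nM. The number for compound 1 sits between the other two, and its distance to each of them lies within the usual scatter of repeated measurements, so the three cannot be told apart with confidence.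

Compound 4 `CCc1ccccc1-c1nc(CN2CCC(C(=O)NCCCN3C[C@H](C)C[C@H](C)C3)CC2)c(C)o1` has not yet been measured. It differs from compound 1 in one place: 2-ethylphenyl in place of 2,3,4,5,6-pentamethylphenyl on an aromatic carbon. The rest of the molecule is kept. Among the compounds with values here, no measured pair in the set isolates this particular exchange, so there is no direct precedent to lean on. The three measured numbers all lie close together. On that basis the step expected in this assay a 1.2-fold lower number from compound 1 to compound 4 (0.07 log units; within the scatter) is small, with no clear direction beyond the scatter. Compound 4 is therefore estimated at 7000 nM, with a range from 3000 nM to 16000 nM.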

Compound 4, half-maximal cytotoxic concentration: 9320 nM
For compound 4 the middle estimate is 1.3-fold (0.12 log units) below the measured one; measured number inside the range.
By their numbers in this assay, from the lowest: compounds 2, 1, 4 and 3 (each within the scatter of the next, the first and the last beyond it).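

Within the data shown here, this is the first one-place comparison in the set: in this assay, putting 2-ethylphenyl in place of 2,3,4,5,6-pentamethylphenyl gives a 1.1-fold higher number from compound 1 to compound 4 (0.06 log units; within the scatter). On this aromatic carbon, then, an aryl group of 11 heavy atoms and one of 8 cannot be told apart by cell tolerance, although the exchange removes all but one of the ring's substituents. Nothing available explains this result, so it stands as an observation only.

Both groups are carbon-only aromatic rings, so these compounds leave open how a plain phenyl, or a pyridine ring with nitrogen in the ring, would read at this position. Equally open, as far as these compounds go, is the outcome for a phenyl ring carrying an amine or a carboxylic acid.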